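The compounds below may be only part of what the source reports. "The series", "measured", "known", "first", "only" and "open" are said of these compounds alone.

Going by the values given here, compound 2 `Cc1ccccc1C(=O)n1c(-c2cn(-c3ccccc3)nc2-c2ccc(C(F)(F)F)cc2)nc2ccccc21` is one of two compounds measured in an ADME assay on HEK-293T cells (Homo sapiens) for cytotoxicity, read by MTT assay, with a stated time of 24 h (a lower number here means that less compound is tolerated, a higher number that more compound is tolerated), where compound 2 gives 179000 nM, the higher of the two numbers, though its companion compound 1 `Cc1ccc(C(=O)n2c(-c3cn(-c4ccccc4)nc3-c3ccc(C(F)(F)F)cc3)nc3ccccc32)cc1` is within the scatter of it: compound 1 gives 169000 nM, and the step of a 1.1-fold higher number from compound 1 to compound 2 (0.02 log units; within the scatter) is too small to count as a real change. The next compound, compound 3 `O=C(c1ccccc1)n1c(-c2cn(-c3ccccc3)nc2-c2ccc(C(F)(F)F)cc2)nc2ccccc21`, differs from compound 2 by hydrogen in place of methyl on an aromatic carbon. Among the compounds with values here, the single step measured so far, which moved the methyl from one place on the same ring to another, left the number where it was, so the only evidence at hand points to the tolerated concentration being insensitive to what sits on this ring. The step from compound 2 to compound 3 is therefore expected to be a 1.1-fold lower number from compound 2 to compound 3 (0.02 log units; within the scatter), nothing beyond the scatter. Compound 3 is estimated to give 170000 nM in this assay, with a likely range from 90000 nM to 320000 nM.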

Compound 3, half-maximal cytotoxic concentration: 168000 nM
The estimate for compound 3 lay 1.0-fold (0.01 log units) above the measured number; the range from low to high includes it.
By their numbers in this assay, from the lowest: compounds 3, 1 and 2 (each within the scatter of the next).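

Taking the methyl off altogether, rather than moving it, is what these results add in this assay: the step of a 1.1-fold lower number from compound 2 to compound 3 (0.03 log units; within the scatter) and the step of a 1.0-fold lower number from compound 1 to compound 3 (0.00 log units; within the scatter) both leave the number unchanged within the scatter. The earlier pair both carried a methyl, so they could not show that the plain benzoyl compound reads the same as the 2-methylphenyl and 4-methylphenyl versions; on this ring, a methyl at either place and hydrogen cannot be told apart. Nothing at hand explains this flat result.

As far as these compounds go, all three compounds carry only hydrogen or methyl on this ring, so it remains open whether an amine, a carboxylic acid or a longer chain there would shift the number. Changes elsewhere on the shared core, such as replacing the trifluoromethyl, also remain open.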